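Pyrazole for phenyl in the biaryl amide series

This account rests on a few compounds, and the source may have more. Where it says the series, first, only, none or still open, it means among the compounds named here.

Compound 1 `CNC(=O)N1CCCc2ccc(NC(=O)c3cccc(-c4ccccc4)c3)cc21` carries a phenyl on the amide-bearing ring and gives 2.83% in a functional assay on MV4-11 cells (Homo sapiens) for antiproliferative activity, with a stated time of 6 days, tested at 1.56 uM; on this read-out lower numbers stand for a weaker effect and higher numbers for a stronger effect at the one concentration tested. Compound 2 `CNC(=O)N1CCCc2ccc(NC(=O)c3ccc(-c4ccccc4)cc3)cc21` gives 19.7% and compound 3 `CNC(=O)N1CCCc2ccc(NC(=O)c3ccc(-c4cnn(C(C)=O)c4)cc3)cc21` gives 23.9%. Compound 1 thus stands lowest of the three numbers, separated from both others by more than the usual scatter.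

Compound 4 `CNC(=O)N1CCCc2ccc(NC(=O)c3cccc(-c4cn[nH]c4)c3)cc21` is not yet measured. It differs from compound 1 in one place: 1H-pyrazol-4-yl in place of phenyl on an aromatic carbon.

Within the data shown here, the only measured step that bears on this change is the one from compound 2 to compound 3, where 1-acetyl-1H-pyrazol-4-yl replaced phenyl on an aromatic carbon: a number 4.2 percentage points higher from compound 2 to compound 3 (within the scatter). That step was small; the present change differs in that the pyrazole enters without the acetyl, and in its place, meta to a large group, so the comparison is only approximate.

Given the small step seen from compound 2 to compound 3, compound 4 is expected to sit near compound 1, with an estimated step of a number 4.2 percentage points higher from compound 1 to compound 4 (within the scatter). Compound 4 is therefore estimated at 7%, in a range from -5% to 20%.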

Compound 4, a percentage reported as inhibition, at one concentration (the size of the read-out at that concentration, not a potency): 27.9%
Estimate against measurement, compound 4: 20.9 percentage points below; the whole stated range lies below it.
By their numbers in this assay, from the lowest: compound 1; then compounds 2, 3 and 4 (each within the scatter of the next).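

Among these compounds, on an aromatic carbon meta to a large group, 1H-pyrazol-4-yl in place of phenyl is a real gain in this assay, with a number 25.1 percentage points higher from compound 1 to compound 4 (beyond the scatter), whereas the only earlier phenyl-to-pyrazole change gave a number 4.2 percentage points higher from compound 2 to compound 3 (within the scatter). That earlier step involved 1-acetyl-1H-pyrazol-4-yl at a different place, so the two steps differ in both substituent and position, and neither difference can be singled out from these compounds. The new group has 1 hydrogen-bond donor and 1 hydrogen-bond acceptor where phenyl has 0 of each, but no data here connect these counts to the step or explain it.

Open, as far as these compounds go, is whether a 1-methyl or 1-acetyl group on the pyrazole nitrogen keeps this gain at the same place. Also open, from the compounds shown here alone, is whether a pyridin-4-yl ring does the same, and, with a single concentration tested, how any of these numbers would translate into potency.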